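Swapping a Styryl-Type Arm for a Dimethoxyphenyl Arm

This account rests on a few compounds, and the source may have more. Where it says the series, first, only, none or still open, it means among the compounds named here.

Measured compounds:
- Compound 1, `COC(=O)/C=C/c1cccc(N(Cc2ccc(/C=C/c3c(F)cccc3F)cc2)C(=O)C(C)C)c1`: 108 nM
- Compound 2, `CCOc1cccc(-c2ccc(CN(C(=O)C3CCCCC3)c3cccc(/C=C/C(=O)OC)c3)cc2)c1`: 147 nM

In an assay on isolated protein with Bile acid receptor (Homo sapiens) as the target (on this read-out higher numbers stand for an effect only at larger amounts of compound and lower numbers for an effect already at smaller amounts), compound 1 shows the lower of the two numbers, but compound 2 sits within the usual scatter of it, so the two cannot be ranked. Compound 3, `COC(=O)/C=C/c1cccc(N(Cc2ccc(-c3c(OC)cccc3OC)cc2)C(=O)C(C)C)c1`, has not been measured. It differs from compound 1 in one place: 2,6-dimethoxyphenyl in place of 2-(2,6-difluorophenyl)ethenyl on an aromatic carbon. Within the data shown here, no step between measured compounds that matches this change is available. A modest weakening is expected, a 2.0-fold higher number from compound 1 to compound 3 (0.31 log units; beyond the scatter), since compound 2 carries a related two-ring group and gives 147 nM. Compound 3 is therefore estimated at 220 nM, expected between 60 nM and 800 nM.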

Compound 3, half-maximal effective concentration: 95 nM
Beside the measured number, compound 3's estimate is 2.3-fold (0.36 log units) above it, and the stated range covers the measured number.
By their numbers in this assay, from the lowest: compounds 3, 1 and 2 (each within the scatter of the next).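

In this assay, putting 2,6-dimethoxyphenyl in place of 2-(2,6-difluorophenyl)ethenyl gives a 1.1-fold lower number from compound 1 to compound 3 (0.06 log units; within the scatter) and so leaves the two groups indistinguishable. This aromatic carbon therefore tolerates an arm that has lost the double bond outside the rings and carries oxygen instead of fluorine, with the number staying within the scatter. Nothing available explains why these two different groups read alike.

Still open, going by these compounds, is whether a plain phenyl ring would read the same at this place. A ring bearing an amine or a carboxylic acid is equally untested here.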